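The source may report more compounds than this note shows. Statements on the series, on what has been measured and on what is new or still open speak of the compounds shown alone.

Three compounds built on the shared core, in which a thioether links a pentanoic acid or its ester to a substituted aromatic ring, have been tested in an assay for inhibition of Polyunsaturated fatty acid 5-lipoxygenase (Homo sapiens), read by HPLC, with a stated time of 10 min; on this read-out lower numbers stand for stronger inhibition and higher numbers for weaker inhibition. Compound 1 `CCCCC(Sc1ccc(OCCCOc2ccc3ncccc3c2)cc1)C(=O)OCC` carries an ethyl ester, and in this assay compound 1 reaches only the limit of > 10000 nM. Compound 2 `CCCCC(Sc1ccc(OCCCOc2cccc(C)c2)cc1)C(=O)O` carries the free acid and a 3-methylphenyl group, and in this assay compound 2 likewise reaches only the limit of > 10000 nM. Compound 3 `CCCCC(Sc1ccc(OCCCOc2ccc(-c3ccccc3)cc2)cc1)C(=O)O` carries the free acid with a phenyl on the outer ring, and in this assay compound 3 gives 3500 nM. So compound 2 stands at the limit of > 10000 nM in this assay, at which 2 of the 3 values shown sit, and no number separates it from compound 1.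

Compound 4 `CCCCC(Sc1ccc(OCCCOc2cccc(C(C)C)c2)cc1)C(=O)O` differs from compound 2 by isopropyl in place of methyl on an aromatic carbon. Among the compounds with values here, no measured pair shows this change, so its size is uncertain; a modest gain is expected, since compound 3 with its larger phenyl gives 3500 nM, a step in the expected range of an at least 1.2-fold lower number from compound 2 to compound 4 (0.09 log units; that floor lies within the scatter). Compound 4 is estimated at 8000 nM, between 3000 nM and 20000 nM.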

Compound 4, half-maximal inhibitory concentration: 6000 nM
Compound 4: middle estimate off by 1.3-fold (0.12 log units), on the high side; the measured number falls inside the stated range.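

Within the data shown here, replacing 3-methylphenyl with 3-isopropylphenyl gives the first step that can be read at all, an at least 1.6-fold lower number from compound 2 to compound 4 (0.22 log units; that floor lies within the scatter), and it shows that a change at this one aromatic carbon can bring a compound from the limit of the assay to a measured number. That step is only a floor because compound 2 has a limit and no number of its own: the limit of > 10000 nM in this assay, at which 2 of the 4 values shown sit. The true size of the change could therefore be larger, but the data do not show by how much.

As far as these compounds go, it remains open whether a still larger group at this place, such as tert-butyl, would lower the number further. Nor do the compounds shown tell how a methoxy group or an amine on this carbon would compare with isopropyl.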